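The compounds below may be only part of what the source reports. "The series", "measured", "known", "first", "only" and "open" are said of these compounds alone.

Measured so far in an ADME assay on microsomes from liver (Homo sapiens) for metabolic stability, with a stated time of 10 min, tested at 0.5 uM; on this read-out lower numbers stand for a less stable compound and higher numbers for a more stable compound:
- compound 1 `CC(C)COc1ncc(-c2cn(C)c3cc(C(=O)NS(C)(=O)=O)ccc23)cc1Cl`: 95%
- compound 2 `CC(C)Cc1ccc(-c2cn(C)c3cc(C(=O)NS(C)(=O)=O)ccc23)cc1`: 100%
- compound 3 `CC(C)COc1ncc(-c2nn(C)c3cc(C(=O)NS(C)(=O)=O)ccc23)cc1Cl`: 100%

Compound 2 reads 100%, the same as compound 3 at the digits shown. Its gap to compound 1 at 95% lies within the usual scatter of this kind of measurement, so the three values cannot be ranked.

The next compound to be read is compound 4 `Cn1cc(-c2ccc(C(F)(F)F)cc2)c2ccc(C(=O)NS(C)(=O)=O)cc21`. Relative to compound 2, it has trifluoromethyl in place of isobutyl on an aromatic carbon of a six-membered aromatic ring of carbon only, para to a large group (trifluoromethyl in place of isobutyl on an aromatic carbon).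

Among the measured compounds shown here, no measured pair isolates this change, so the expectation rests only on the general level of the series in this assay. That level is set by compound 1 at 95%, compound 2 at 100% and compound 3 at 100%. For the measured compounds named here, with only three compounds, all within the scatter of each other, the data give no direction for this change, and no shift beyond the scatter is expected. The expected step is a number 4 percentage points lower from compound 2 to compound 4 (within the scatter), which stays within the scatter. For compound 4 the estimated value is 96%, with an expected range of 85% to 100%.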

Compound 4, percent of the compound remaining: 100%
Beside the measured number, compound 4's estimate is 4 percentage points below it; measured number inside the range.
By their numbers in this assay, from the lowest: compounds 1, 2, 3 and 4 (each within the scatter of the next).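

In this assay, among the compounds shown here, trifluoromethyl in place of isobutyl on an aromatic carbon gives no change at the digits printed from compound 2 to compound 4 (within the scatter), the first step that can be read across a single place. At this position, para to a large group, the read-out therefore does not separate the two groups, and compound 4 at 100% stays at the level of the other compounds in the series. Nothing available explains why the exchange leaves the reading flat.

Going by these compounds, whether any group at this position can pull the percent remaining down beyond the scatter stays open, for example a primary amine, a carboxylic acid or a longer chain such as n-hexyl. For the compounds shown here, also open is whether the same exchange would read the same way on the cores of compound 1 and compound 3, since this single step comes from the core shared by compound 2 and compound 4 and the series so far holds no matching pair on either of the other two.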